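The source may hold more compounds than are shown below. What is called first, only, known or untested is meant among the compounds shown, and "the series" means these compounds.

Three compounds have been measured in an in vitro functional assay on 1321-N1 cells for agonist activity at Free fatty acid receptor 1 (Homo sapiens), read by fluorescence, spectrophotometry and calcium flux; a higher number here means a larger maximal response, a lower number a smaller maximal response:

compound 1, `O=C(O)CCc1ccc(C#Cc2ncccc2[N+](=O)[O-])cc1`: 87%
compound 2, `O=C(O)CCc1ccc(C#Cc2cccs2)cc1`: 97%
compound 3, `O=C(O)CCc1ccc(C#Cc2ccnc(Cl)c2)cc1`: 94%

Among the measured compounds shown here, of the three numbers, the one for compound 2 is the highest, yet the gap to compound 3 and the gap to compound 1 both lie within the usual scatter of repeated measurements, so nothing in this assay separates the three compounds from one another. For the measured compounds named here, no single-point step between measured compounds is available.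

Compound 4, `Cc1ccsc1C#Cc1ccc(CCC(=O)O)cc1`, has not yet been measured. It differs from compound 2 in one place: methyl in place of hydrogen on an aromatic carbon. The same difference, cut one bond further out, reads thiophen-2-yl to 3-methylthiophen-2-yl.

Given that compound 2 already gives 97% in this assay, and that the three measured compounds all sit close together, the step from compound 2 to compound 4 is expected to be small, estimated at a number 2 percentage points lower from compound 2 to compound 4 (within the scatter), with no direction beyond the scatter. The value for compound 4 is therefore estimated at 95%, expected to fall between 75% and 110%.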

Compound 4, largest response reached (reported as efficacy), in percent of the reference or control that the assay uses: 100%
Compound 4: the middle estimate sits 5 percentage points below what was measured, and the stated range covers the measured number.
By their numbers in this assay, from the lowest: compounds 1, 3, 2 and 4 (each within the scatter of the next, the first and the last beyond it).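

In this assay, among the compounds shown here, the change from thiophen-2-yl to 3-methylthiophen-2-yl gives the first single-place step in this set, a number 3 percentage points higher from compound 2 to compound 4 (within the scatter). For the compounds shown here, the aromatic carbon next to the ring atom that bears a large group therefore carries a methyl without a maximal response that can be told apart from that of the unsubstituted ring, something the earlier compounds, which differ in more than one place, could not show. Nothing available explains this step.

The compounds shown leave open whether an ethyl, a methoxy group or an amine on this same carbon would give a maximal response like that of the methyl in this assay. They also leave open whether a methyl on another carbon of the ring, or on the ring of compound 3, would give a similar step.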